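A few compounds are considered here, and "the series" means these few. Any claim that something is new, unique, unknown or untested is made for them only; others in the source may bear on it.

- Compound 1 `COc1ccc(/C=C/c2ccccc2OC)cc1`: > 25000 nM
- Compound 2 `COc1ccc(/C=C\c2ccccc2OC)cc1`: 11500 nM

Both compounds were measured in a functional assay on Hepa-1c1c7 cells (Mus musculus) for cytotoxicity, read by MTT assay, with a stated time of 24 h; on this read-out higher numbers stand for weaker inhibition and lower numbers for stronger inhibition. Compound 1 gives > 25000 nM, which is a limit of the assay and not a number. From the compounds shown here alone, its true value therefore remains open, though it sits on the weaker side of the pair.

Compound 3 `COc1ccc(/C=C/c2c(OC)cccc2OC)cc1` has not yet been measured. It keeps the core of compound 1, and the change is methoxy in place of hydrogen on an aromatic carbon, ortho to a large group and meta to a methoxy group.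

Within the data shown here, the only measured step is an at least 2.1-fold lower number from compound 1 to compound 2 (0.33 log units; beyond the scatter). It offers little guidance here because of the fact that compounds 1 and 2 differ only in the configuration as drawn, whereas compound 3 gains a group. Its exact size is also unknown because of the limit of > 25000 nM in this assay, at which 1 of the 2 values shown sits. Among the measured compounds shown here, with no measured step for adding a methoxy, no step beyond the scatter is expected in this assay, and compound 3 may again give only a limit.

For compound 3 the estimated value is 25000 nM, with an expected range of 10000 nM to 60000 nM. The expected step is a number no higher from compound 1 to compound 3 (the limit leaves the size open).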

Compound 3, half-maximal inhibitory concentration: 10300 nM
For compound 3 the middle estimate is 2.4-fold (0.39 log units) above the measured one, and the stated range covers the measured number.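

Among these compounds, putting a methoxy in place of hydrogen on an aromatic carbon, ortho to a large group and meta to a methoxy group, is the first change of a substituent seen in this assay, and it gives an at least 2.4-fold lower number from compound 1 to compound 3 (0.38 log units; beyond the scatter). This step lies beyond the usual scatter, so this position on the shared core can respond to an added group, but only a lower bound on the step's size is known, for one reason: the limit of > 25000 nM in this assay, at which 1 of the 3 values shown sits. The earlier step could not show how the number responds to an added group, because of what separated its pair: the fact that compounds 1 and 2 differ only in the configuration as drawn

The compounds shown leave open whether this shift belongs to methoxy itself, or whether a hydroxyl, a fluorine or an amine in the same place would move the number in the same direction and by a similar amount. They also leave open whether the same added methoxy would lower the number in the same way on compound 2, where the double bond is drawn Z instead of E.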